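Trading a Benzyl Group for Isopropyl on the Ring Nitrogen

The source may hold more compounds than are shown below. What is called first, only, known or untested is meant among the compounds shown, and "the series" means these compounds.

Of the compounds shown here, three have been measured in a functional assay on cells (Platelet, Homo sapiens) for inhibition; on this read-out higher numbers stand for weaker inhibition and lower numbers for stronger inhibition. Compound 1 `CCOC(=O)c1cccc(-c2n[nH]c3ccccc23)c1` carries no group on its ring nitrogen and gives 5650 nM. Compound 2 `CCOC(=O)c1ccc(-c2nn(Cc3cccc(F)c3)c3ccccc23)cc1`, whose ring nitrogen bears a benzyl group carrying a fluoro, gives 270 nM, and compound 3 `CCOC(=O)c1ccc(-c2nn(Cc3cccc(OC)c3)c3ccccc23)cc1`, bearing a 3-methoxybenzyl group there, gives 260 nM. Compound 3 thus holds the lowest number shown, with compound 2 indistinguishable from it: the single measured change, a 1.0-fold lower number from compound 2 to compound 3 (0.02 log units; within the scatter), shows that the group on the benzyl ring is hardly felt. Compound 1 differs from both in two places, so its far higher number cannot be pinned to either.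

Compound 4 `CCOC(=O)c1ccc(-c2nn(C(C)C)c3ccccc23)cc1` is the next step: isopropyl in place of 3-methoxybenzyl on an aromatic nitrogen. Among the measured compounds shown here, no measured step removes the aromatic ring of the benzyl group, so the step from compound 2 to compound 3 says nothing about whether that ring itself matters. Because compound 1 gives 5650 nM without any group on the nitrogen, a shrunken group is expected to weaken inhibition, an estimated 5.8-fold higher number from compound 3 to compound 4 (0.76 log units; beyond the scatter). Compound 4 is therefore expected to give 1500 nM, likely between 400 nM and 6000 nM.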

Compound 4, half-maximal inhibitory concentration: 650 nM
Beside the measured number, compound 4's estimate is 2.3-fold (0.36 log units) above it; the measured number falls inside the stated range.
By their numbers in this assay, from the lowest: compounds 3 and 2 (each within the scatter of the next); then compound 4; then compound 1.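

Among the compounds shown here, this is the first step that removes the aromatic ring from the group on the aromatic nitrogen, replacing it with the smaller, ring-free isopropyl. The change costs something, but not much: there is a 2.5-fold higher number from compound 3 to compound 4 (0.40 log units; beyond the scatter), and from the fluorinated benzyl group there is a 2.4-fold higher number from compound 2 to compound 4 (0.38 log units; beyond the scatter), so both steps are modest, although beyond the scatter. Nothing available explains why the number moves with this change.

Still open, as far as these compounds go, is how the number would respond to a plain methyl, a longer chain such as butyl, or a chain ending in an amine on this nitrogen. The compounds shown also leave unknown what a carboxylic acid would do in place of the ethyl ester.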